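Positional isomers on the urea aryl group in one series

A few compounds are considered here, and "the series" means these few. Any claim that something is new, unique, unknown or untested is made for them only; others in the source may bear on it.

Measured so far:
- Compound 1 `CN(C)C1(Cc2ccccc2)CCN(c2cc(C(F)(F)F)ccc2CNC(=O)Nc2cccc3ccc(O)cc23)CC1`: "not active" (no number reported)
- Compound 2 `CN(C)C1(Cc2ccccc2)CCN(c2cc(C(F)(F)F)ccc2CNC(=O)Nc2cccc3c(=O)[nH]ccc23)CC1`: 43.7 nM
- Compound 3 `CN(C)C1(Cc2ccccc2)CCN(c2cc(C(F)(F)F)ccc2CNC(=O)Nc2ccc3ccncc3c2)CC1`: "not active" (no number reported)

In an assay on CHO cells for agonist activity at transient receptor potential cation channel subfamily V member 1 (Homo sapiens), read by scintillation counting, with a stated time of 5 min, in the presence of a further agent that is not named here (a higher number here means that more compound is needed for the effect, a lower number that less compound is needed), compound 2 gives 43.7 nM, the only numerical result in this set. Compound 3 is reported as "not active" (no number reported) in this assay, with no number, as is compound 1, so compound 3 has no measured place on a scale here. Compound 4 `CN(C)C1(Cc2ccccc2)CCN(c2cc(C(F)(F)F)ccc2CNC(=O)Nc2ccc3cnccc3c2)CC1` is its isomer: isoquinolin-6-yl in place of isoquinolin-7-yl on an amide-type nitrogen. With no step between measured compounds shown, and compound 3 itself without a number, there is no basis to expect a defined direction or size of change in this assay. The estimate for compound 4 is 1500 nM, with an expected range of 150 nM to 15000 nM, and a substantial chance that this assay again reports no number.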

Compound 4, half-maximal effective concentration: "not active" (no number reported)
Compound 4 has no reported number here; no gap can be computed for the estimate.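

Compound 3 and compound 4 both stand without a number, so no step can be read between them, and no supporting data bear on this result. The compounds shown leave open whether isoquinolin-7-yl and isoquinolin-6-yl differ at all.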